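Oxime Ether Side Chains and Antiproliferative Potency

This account rests on a few compounds, and the source may have more. Where it says the series, first, only, none or still open, it means among the compounds named here.

Compound 1 `CCN(CC)C(=O)CO/N=C(\c1ccc(SC)cc1)c1cccc2ccccc12` reaches only a limit in a functional assay on Ishikawa cells (Homo sapiens) for antiproliferative activity, read by MTT assay, with a stated time of 24 h (a higher number here means that more compound is needed for the effect, a lower number that less compound is needed), namely > 50000 nM.
Compound 2 `CSc1ccc(/C(=N\OCCCCN2CCCCC2)c2cccc3ccccc23)cc1` gives 18000 nM in this assay.

Compound 2 therefore holds the only real number shown, while the other value is a limit (the limit of > 50000 nM in this assay, at which 1 of the 2 values shown sits). Compound 3 `CCN(CCCCO/N=C(\c1ccc(SC)cc1)c1cccc2ccccc12)Cc1ccccc1` differs from compound 2 by benzyl(ethyl)amino in place of piperidin-1-yl on a saturated chain carbon, four bonds along the chain from an oxygen. Within the data shown here, the single measured step, an at least 2.7-fold lower number from compound 1 to compound 2 (0.44 log units; beyond the scatter), concerns the group attached at the chain oxygen rather than the amine end of the chain, so it offers little guidance for this change. A step within the usual scatter is expected, and compound 3 is estimated at 18000 nM, with a range from 6000 nM to 50000 nM. This estimate means no change at the digits printed from compound 2 to compound 3 (within the scatter).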

Compound 3, half-maximal effective concentration: > 50000 nM
Compound 3 was reported as a limit; the forecaster's own chance of this, stated with the estimate: 15%; middle value at least 2.7-fold (0.44 log units) away from the limit.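

In this assay, the amine at the chain end matters: benzyl(ethyl)amino in place of piperidin-1-yl gives an at least 2.7-fold higher number from compound 2 to compound 3 (0.44 log units; beyond the scatter). Among these compounds, the earlier step replaced diethylcarbamoyl and left this amine end unexplored, so this is the first comparison to vary it directly. Compound 3 reaches only a limit, so the full size of the step stays unknown: the limit of > 50000 nM in this assay, at which 2 of the 3 values shown sit.

The compounds shown leave open whether only the piperidin-1-yl ring supports a measurable number here. A morpholin-4-yl or a dimethylamino group at the same chain end could test that.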